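A few compounds are considered here, and "the series" means these few. Any claim that something is new, unique, unknown or untested is made for them only; others in the source may bear on it.

Working notes on the thioether series, tested in a functional assay on PC-9 cells (Homo sapiens) for inhibition, read by MTT assay, with a stated time of 72 h; on this read-out lower numbers stand for stronger inhibition and higher numbers for weaker inhibition. Compound 3 `COc1ccc(CSc2nc3nc(C)cc(Nc4cc(-c5ccccc5)[nH]n4)n3n2)cc1` gives 8110 nM, and compound 2 `Cc1cc(Nc2cc(-c3ccccc3)[nH]n2)n2nc(SCc3nc4ccccc4[nH]3)nc2n1` gives 4840 nM. Going by the values given here, these are the only two numeric values so far, and a 1.7-fold higher number from compound 2 to compound 3 (0.22 log units; within the scatter) leaves them level. Compound 1 `C=CCSc1nc2nc(C)cc(Nc3cc(-c4ccccc4)[nH]n3)n2n1` gives > 50000 nM, which is a limit of the assay and not a number.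

Compound 4 `CCCSc1nc2nc(C)cc(Nc3cc(-c4ccccc4)[nH]n3)n2n1` has ethyl in place of 4-methoxyphenyl on a saturated chain carbon bound to a sulfur. This removes the ring from that group, and the relevant evidence comes from compound 1, which also has no ring there. Both ring-bearing groups improve on its vinyl: an at least 10-fold lower number from compound 1 to compound 2 (1.01 log units; beyond the scatter) is large, and an at least 6.1-fold lower number from compound 1 to compound 3 (0.78 log units; beyond the scatter) is at least modest. Neither of the two compounds goes against this pattern. Reversing that second step suggests a clearly higher number in this assay, of modest to large size, and a limit rather than a number is quite possible. The expected change is a 4.9-fold higher number from compound 3 to compound 4 (0.69 log units; beyond the scatter). For compound 4 the estimated value is 40000 nM, with an expected range of 15000 nM to 80000 nM.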

Compound 4, half-maximal inhibitory concentration: > 50000 nM
Compound 4 was reported as a limit; the forecaster's own chance of this, stated with the estimate: 55%; middle value at least 1.2-fold (0.09 log units) away from the limit.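

In this assay, ethyl in place of 4-methoxyphenyl on a saturated chain carbon bound to a sulfur gives an at least 6.1-fold higher number from compound 3 to compound 4 (0.78 log units; beyond the scatter), and ethyl in place of 1H-benzimidazol-2-yl gives an at least 10-fold higher number from compound 2 to compound 4 (1.01 log units; beyond the scatter). Going by these compounds alone, the weak result at this position is therefore not confined to vinyl: among the four compounds, the two ring-bearing groups give numbers, the two groups without a ring do not, and no compound goes against this. Compound 1 and compound 4 each stand at a limit of the assay and not at a number, so the step between them cannot be read: the limit of > 50000 nM in this assay, at which 2 of the 4 values shown sit.

From the compounds shown here alone, whether a ring is required stays open, since a longer chain such as octyl or a saturated ring such as cyclohexyl could separate ring from size. Compound 2 and compound 3 are level, so nothing yet favours either ring-bearing group.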